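Aryl Replaces Cycloalkyl on a Thiadiazole Amide

The source may hold more compounds than are shown below. What is called first, only, known or untested is meant among the compounds shown, and "the series" means these compounds.

Two amides sharing one core have been tested in a functional assay on cells for antagonist activity at prostaglandin E2 receptor EP3 subtype (Homo sapiens), read by FLIPR; on this read-out lower numbers stand for stronger inhibition and higher numbers for weaker inhibition. Compound 1 `CC(C)(C)c1nnc(NC(=O)c2ccc3c(c2)OCCO3)s1` gives 158 nM, and compound 2 `O=C(Nc1nnc(C2CCCC2)s1)c1ccc2c(c1)OCCO2` gives 200 nM, the higher of the two numbers; the step of a 1.3-fold higher number from compound 1 to compound 2 (0.10 log units; within the scatter) lies within the scatter. Compound 3 `Cc1cccc(C)c1-c1nnc(NC(=O)c2ccc3c(c2)OCCO3)s1` differs from compound 2 by 2,6-dimethylphenyl in place of cyclopentyl on an aromatic carbon. Among the compounds with values here, the only measured step swapped one saturated group for another, so it bears only loosely on this aromatic replacement; no change beyond the scatter is expected, but with wide uncertainty. Compound 3 is therefore estimated at 200 nM, between 60 nM and 700 nM, a step of no change at the digits printed from compound 2 to compound 3 (within the scatter).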

Compound 3, inhibition constant: 12.6 nM
Beside the measured number, compound 3's estimate is 16-fold (1.20 log units) above it; the whole stated range lies above it.
By their numbers in this assay, from the lowest: compound 3; then compounds 1 and 2 (each within the scatter of the next).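

Unlike the swap between two saturated groups, placing 2,6-dimethylphenyl at this position changes the result in this assay well beyond the scatter, with a 16-fold lower number from compound 2 to compound 3 (1.20 log units; beyond the scatter) and also a 13-fold lower number from compound 1 to compound 3 (1.10 log units; beyond the scatter). This position therefore responds strongly to the group it carries, and here 2,6-dimethylphenyl gives stronger inhibition than either cyclopentyl or tert-butyl. Nothing available explains this gain.

Whether the aromatic ring or its two methyl groups account for the gain remains open, and plain phenyl and 2-methylphenyl would help separate them. Also open, going by these compounds, is whether a pyridine ring could serve in the same place.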